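The source may hold more compounds than are shown below. What is called first, only, known or untested is meant among the compounds shown, and "the series" means these compounds.

Measured compounds:
Compound 1 `CCOC(=O)Nc1cc(NC(C)C(=O)COc2ccccc2)c([N+](=O)[O-])c(N)n1` — in a functional assay on L1210 cells (Mus musculus), with a stated time of 48 h (a lower number here means a stronger inhibitor, a higher number a weaker inhibitor), compound 1 gives 89000 nM.
Compound 2 `CCCCC(=O)C(C)Nc1cc(NC(=O)OCC)nc(N)c1[N+](=O)[O-]` — compound 2 gives 54000 nM.
Compound 3 `CCOC(=O)Nc1cc(NC(C)C(O)COc2ccccc2)c(N)c(N)n1` — compound 3 gives 21000 nM.

From compound 1 to compound 2 the change is propyl in place of phenoxy on a saturated chain carbon bound to a carbonyl carbon, and it made a 1.6-fold lower number from compound 1 to compound 2 (0.22 log units; within the scatter). Compound 3 stands apart from compound 1 in more than one place; the difference between the two cores is not broken down here. Compound 4 `CCCCC(O)C(C)Nc1cc(NC(=O)OCC)nc(N)c1N` has not yet been measured. From compound 3 to compound 4 the change is propyl in place of phenoxy on a saturated chain carbon, two bonds along the chain from an oxygen on a saturated carbon. For the measured compounds named here, this is the same kind of change as the one from compound 1 to compound 2, but the place differs: there the carbon is bound to a carbonyl carbon, here it lies two bonds along the chain from an oxygen on a saturated carbon. A step of similar size is expected, because the earlier one read a 1.6-fold lower number from compound 1 to compound 2 (0.22 log units; within the scatter); the estimated step is a 1.4-fold lower number from compound 3 to compound 4 (0.15 log units; within the scatter). Compound 4 is expected to give about 15000 nM, between 6000 nM and 40000 nM.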

Compound 4, half-maximal inhibitory concentration: 18000 nM
Compound 4: middle estimate off by 1.2-fold (0.08 log units), on the low side, and the stated range covers the measured number.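

In this assay, propyl in place of phenoxy gave a 1.2-fold lower number from compound 3 to compound 4 (0.07 log units; within the scatter). Set beside the earlier case, the change reads alike on the two cores: the same change on two cores in this assay, a 1.6-fold lower number (0.22 log units; within the scatter) from compound 1 to compound 2 and a 1.2-fold lower number (0.07 log units; within the scatter) from compound 3 to compound 4, 1.4-fold (0.15 log units) apart, within the scatter of two such steps. This shows that, on these two cores, the swap gave steps of matching size that stay within the scatter, but two small steps do not show that it would read the same on any other core in the series, or that propyl improves on phenoxy.

The compounds shown leave open whether a different group at this place, such as an amine, a carboxylic acid or a longer chain, would give a step beyond the scatter.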